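Series notes: from compound 3 to compound 4

A few compounds are considered here, and "the series" means these few. Any claim that something is new, unique, unknown or untested is made for them only; others in the source may bear on it.

compound 1 `FC(F)(F)c1cccc(NC(=S)Nc2ccc(Cl)cc2)c1`: 10000 nM
compound 2 `CCCC[C@H]1CC[C@H](c2ccc(NC(=S)Nc3cccc(C(F)(F)F)c3)cc2)CC1`: 9500 nM
compound 3 `FC(F)(F)c1cccc(NC(=S)Nc2ccccc2)c1`: 41000 nM

In an ADME assay on BHK cells (Mesocricetus auratus) for cytotoxicity, read by MTT assay, with a stated time of 96 h (a lower number here means that less compound is tolerated, a higher number that more compound is tolerated), compound 3 stands highest of the three at 41000 nM. Compound 4 `CCOC(=O)c1ccc(NC(=S)Nc2cccc(C(F)(F)F)c2)cc1` has ethoxycarbonyl in place of hydrogen on an aromatic carbon, para to a large group (ethoxycarbonyl in place of hydrogen on an aromatic carbon). Within the data shown here, two measured steps bear on this, both with hydrogen entering in place of another group: a 4.1-fold higher number from compound 1 to compound 3 (0.61 log units; beyond the scatter) and a 4.3-fold higher number from compound 2 to compound 3 (0.64 log units; beyond the scatter). Between the two groups themselves, a 1.1-fold lower number from compound 1 to compound 2 (0.02 log units; within the scatter). Among the measured compounds shown here, no measured compound carries ethoxycarbonyl, so the size is carried over from those steps, read in reverse. The expected step is a 3.7-fold lower number from compound 3 to compound 4 (0.57 log units; beyond the scatter), towards a lower number. Compound 4 is estimated at 11000 nM (expected range 4000 nM to 30000 nM).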

Compound 4, half-maximal cytotoxic concentration: 50000 nM
Compound 4: the middle estimate sits 4.5-fold (0.66 log units) below what was measured; measured number outside the range, above it.
By their numbers in this assay, from the lowest: compounds 2 and 1 (each within the scatter of the next); then compounds 3 and 4 (each within the scatter of the next).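

In this assay, ethoxycarbonyl on an aromatic carbon, para to a large group, does not behave like chloro or 4-butylcyclohexyl at this position: a 1.2-fold higher number from compound 3 to compound 4 (0.09 log units; within the scatter), so a group here need not bring a lower number. Set against those two groups, ethoxycarbonyl gives a 5.0-fold higher number from compound 1 to compound 4 (0.70 log units; beyond the scatter) and a 5.3-fold higher number from compound 2 to compound 4 (0.72 log units; beyond the scatter). No evidence is at hand to explain this split among the groups. On these data alone, whether an amine, a carboxylic acid or a longer ester chain here would sit with compound 3 and compound 4 or with compound 1 and compound 2 stays open.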